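The compounds below may be only part of what the source reports. "The series", "measured", "known", "first", "only" and "open" are said of these compounds alone.

Three measured compounds share a core. Compound 1 `COc1cc(OC)c(/C=C/S(=O)(=O)Cc2ccc(OC)c([N+](=O)[O-])c2)c(OC)c1`, compound 2 `COc1cc(OC)c(/C=C/S(=O)(=O)Cc2ccc(Br)c([N+](=O)[O-])c2)c(OC)c1` and compound 3 `COC(=O)C(Nc1cc(CS(=O)(=O)/C=C/c2c(OC)cc(OC)cc2OC)ccc1OC)c1ccc(Br)cc1` were all tested in a functional assay on K562 cells (Homo sapiens) for cytotoxicity, read by trypan blue exclusion, with a stated time of 96 h; on this read-out higher numbers stand for weaker inhibition and lower numbers for stronger inhibition. In this assay compound 1 gives 2500 nM, compound 2 gives 25000 nM and compound 3 gives 200 nM, so compound 3 shows the lowest number of the three.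

Compound 2 and compound 3 differ in more than one place, and the difference between their cores is not broken down here. Compound 1 and compound 2, however, differ in one place only: methoxy in place of bromo on an aromatic carbon. That single exchange produced a 10-fold lower number from compound 2 to compound 1 (1.00 log units; beyond the scatter).

Compound 4 `COC(=O)C(Nc1cc(CS(=O)(=O)/C=C/c2c(OC)cc(OC)cc2OC)ccc1OC)c1ccc(OC)cc1` has not yet been measured. It arises from compound 3 by methoxy in place of bromo on an aromatic carbon. Among the measured compounds shown here, this is the same kind of change as the one from compound 2 to compound 1, but the surroundings are not identical: in compound 2 the bromo sits on an aromatic carbon that is ortho to a nitro group (3 heavy atoms) and para to a large group, whereas in compound 3 it sits on an aromatic carbon para to a large group, with no nitro group counted around it.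

For the measured compounds named here, because a 10-fold lower number from compound 2 to compound 1 (1.00 log units; beyond the scatter) was observed at a differently described place and is the only example seen, the step from compound 3 to compound 4 is expected to be more modest, about a 1.7-fold lower number from compound 3 to compound 4 (0.22 log units; within the scatter). In this assay compound 4 is therefore estimated to give roughly 120 nM, most likely between 40 nM and 400 nM.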

Compound 4, half-maximal inhibitory concentration: 150 nM
For compound 4 the middle estimate is 1.3-fold (0.10 log units) below the measured one, within the range that was stated.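

In this assay, the exchange of bromo for methoxy on the core of compound 3, which turns a 4-bromophenyl into a 4-methoxyphenyl, gave a 1.3-fold lower number from compound 3 to compound 4 (0.12 log units; within the scatter), so on this core the swap cannot be told apart from the ordinary variation between repeated measurements. The same exchange therefore did not carry over at the same size from one core to the other: the same change on two cores in this assay, a 10-fold lower number (1.00 log units; beyond the scatter) from compound 2 to compound 1 and a 1.3-fold lower number (0.12 log units; within the scatter) from compound 3 to compound 4, 7.5-fold (0.88 log units) apart, beyond the scatter of two such steps. Among the compounds shown here, this shows that a large step seen on one core cannot simply be assumed for another, but with only two pairs it does not show what sets the size of the step, since compound 2 carries a nitro group that compound 3 lacks and that is only one of several differences between the cores.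

Going by these compounds, it remains open whether a third core would follow the large step, the small one, or neither, and whether another group in this same place, such as an amine, a hydroxyl or a longer chain like ethoxy, would shift the number beyond the scatter. Also open, on these data alone, is how compound 4 would respond if its methyl ester were replaced by a carboxylic acid.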